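Swapping the side group on the shared core

This account rests on a few compounds, and the source may have more. Where it says the series, first, only, none or still open, it means among the compounds named here.

Compound 3 `COCOC/C1=C/C[C@](C)(CCC=C(C)C)/C=C/[C@@H](OC(=O)C=C(C)C)[C@](C)(O)/C=C/C1=O` gives 3710 nM in a functional assay on SW480 cells (Homo sapiens) for antiproliferative activity, read by MTT assay, with a stated time of 48 h (a higher number here means a weaker inhibitor, a lower number a stronger inhibitor), and sits level with its two measured relatives. Compound 1 `CC[Si](CC)(CC)C/C1=C/C[C@](C)(CCC=C(C)C)/C=C/[C@@H](OC(=O)C=C(C)C)[C@](C)(O)/C=C/C1=O` gives 2690 nM in the same test, and compound 2 `CC(C)=CCC[C@]1(C)/C=C/[C@@H](OC(=O)C=C(C)C)[C@](C)(O)/C=C/C(=O)/C(C[Si](C)(C)C(C)(C)C)=C\C1` gives 3350 nM there too. The steps reaching compound 3 (a 1.4-fold higher number from compound 1 to compound 3 (0.14 log units; within the scatter) and a 1.1-fold higher number from compound 2 to compound 3 (0.04 log units; within the scatter)) lie within the scatter, as does the remaining one (a 1.2-fold higher number from compound 1 to compound 2 (0.10 log units; within the scatter)), so the three compounds cannot be ranked.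

Compound 4 `CCN(CC)C(=O)/C1=C/C[C@](C)(CCC=C(C)C)/C=C/[C@@H](OC(=O)C=C(C)C)[C@](C)(O)/C=C/C1=O` has not yet been measured. It carries diethylcarbamoyl in place of (methoxymethoxy)methyl on a double-bonded ring carbon and thus differs from compound 3 in that one place. The measured steps bear on this change only in part. Each swaps a group on a saturated chain carbon bound to a double-bonded ring carbon, whereas here the whole group on the ring carbon is replaced. Among the compounds with values here, no measured compound carries diethylcarbamoyl. Compound 3 was reached from compound 1 by a step within the scatter (a 1.4-fold higher number from compound 1 to compound 3 (0.14 log units; within the scatter)), so no step beyond the scatter is expected, and no direction is favoured. The estimated step in this assay is a 1.1-fold lower number from compound 3 to compound 4 (0.03 log units; within the scatter) (none beyond the scatter). The estimated value for compound 4 is 3500 nM (expected range 1500 nM to 8500 nM), kept wide for the untested group.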

Compound 4, half-maximal inhibitory concentration: 11700 nM
Compound 4: the middle estimate sits 3.3-fold (0.52 log units) below what was measured; measured number above the stated range.
By their numbers in this assay, from the lowest: compounds 1, 2 and 3 (each within the scatter of the next); then compound 4.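

In this assay, this double-bonded ring carbon no longer looks indifferent to what it carries. The three earlier groups, each joined through a saturated chain carbon, stayed within the scatter of one another, whereas diethylcarbamoyl, which places a carbonyl directly on the ring carbon, gives a step beyond it (a 3.2-fold higher number from compound 3 to compound 4 (0.50 log units; beyond the scatter)). The loss is modest but appears against each of the two silicon-bearing groups as well (a 3.5-fold higher number from compound 2 to compound 4 (0.54 log units; beyond the scatter) and a 4.3-fold higher number from compound 1 to compound 4 (0.64 log units; beyond the scatter)), so it does not depend on which earlier compound is taken as the reference. No accompanying measurement accounts for this shift.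

Whether the loss belongs to the carbonyl sitting directly on the ring carbon or to the two ethyl groups stays open, since diethylcarbamoyl is the only group of its kind shown here. A primary carboxamide, a carboxylic acid or a methyl ester on the same ring carbon, or a diethylaminomethyl group that keeps the saturated chain carbon, would begin to separate these two possibilities.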